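Fluoro to Bromo Exchange on Two Related Cores

This account rests on a few compounds, and the source may have more. Where it says the series, first, only, none or still open, it means among the compounds named here.

Measured compounds:
compound 1, `COc1cc(N(Cc2ccc(F)cc2)S(=O)(=O)c2ccc(C)cc2)cc(OC)c1OC`, 20700 nM
compound 2, `COc1cc(N(Cc2ccc(Br)cc2)S(=O)(=O)c2ccc(C)cc2)cc(OC)c1OC`, 4680 nM
compound 3, `COc1cc(N(Cc2nc3ccccc3[nH]2)C(=O)c2ccc(F)cc2)cc(OC)c1OC`, 21900 nM

Compounds 1 and 2 share a core and differ by bromo in place of fluoro on an aromatic carbon. In a functional assay on PC-3 cells (Homo sapiens) for inhibition, read by MTT assay, with a stated time of 48 h (on this read-out higher numbers stand for weaker inhibition and lower numbers for stronger inhibition), this change gave a 4.4-fold lower number from compound 1 to compound 2 (0.65 log units; beyond the scatter). Compound 3 sits on a different core; the difference between the two cores is not broken down here. Its value in this assay is within the scatter of that of compound 1, and compound 2 stands apart from compound 3 by a margin beyond the scatter.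

Compound 4, `COc1cc(N(Cc2nc3ccccc3[nH]2)C(=O)c2ccc(Br)cc2)cc(OC)c1OC`, is not yet measured. It differs from compound 3 by bromo in place of fluoro on an aromatic carbon, the same change that turned compound 1 into compound 2, on an aromatic carbon of a six-membered aromatic ring of carbon only, para to a large group, though cut one bond further out it reads (4-fluorophenyl)carbonyl to (4-bromophenyl)carbonyl rather than 4-fluorobenzyl to 4-bromobenzyl. Among the compounds with values here, the expectation for compound 4 is a step of a 2.9-fold lower number from compound 3 to compound 4 (0.47 log units; beyond the scatter) in this assay, somewhat smaller than the earlier one because the step from compound 1 to compound 2 was a 4.4-fold lower number from compound 1 to compound 2 (0.65 log units; beyond the scatter) on a different core and only one such example exists. Compound 4 is estimated at 7500 nM, with a likely range from 2500 nM to 22000 nM.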

Compound 4, half-maximal inhibitory concentration: 19900 nM
Compound 4: the middle estimate sits 2.7-fold (0.42 log units) below what was measured; the range from low to high includes it.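

In this assay, bromo in place of fluoro on the core of compound 3 gave a 1.1-fold lower number from compound 3 to compound 4 (0.04 log units; within the scatter), so the step seen on the core of compound 1 did not carry over to this second core: the same change on two cores in this assay, a 4.4-fold lower number (0.65 log units; beyond the scatter) from compound 1 to compound 2 and a 1.1-fold lower number (0.04 log units; within the scatter) from compound 3 to compound 4, 4.0-fold (0.60 log units) apart, beyond the scatter of two such steps The exchange therefore cannot be treated as a change that moves the number by a similar amount on any core of this series, since it acted beyond the scatter on one core and within it on the other. This does not show what sets the two results apart, since the cores differ in more than one place, the change itself reads 4-fluorobenzyl to 4-bromobenzyl on one and (4-fluorophenyl)carbonyl to (4-bromophenyl)carbonyl on the other, and each core offers a single pair.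

The compounds shown leave open how chloro, methyl or an amine at the same place would read on either core. They also leave open whether any exchange on that ring moves the number on the core of compound 3.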